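Methyl to methoxy on the shared core: an expected small step

A few compounds are considered here, and "the series" means these few. Any claim that something is new, unique, unknown or untested is made for them only; others in the source may bear on it.

Of the compounds shown here, three built on a shared core have been tested in a functional assay on U2OS cells (Homo sapiens) for inhibition, read by CCK-8 assay, with a stated time of 72 h, tested at 1 uM; on this read-out lower numbers stand for less inhibition and higher numbers for more inhibition at the one concentration tested (going by the name of the read-out). Compound 1 `COc1ccccc1N1C(=O)C(C)SC1c1cccc(C(=O)NCCCCc2ccccc2)c1` gives 38%. Compound 2 `COc1ccccc1N1C(=O)CSC1c1cc(F)cc(C(=O)O)c1` gives 15%. Compound 3 `COc1ccc(C)cc1N1C(=O)CSC1c1cccc(C(=O)NCCCCc2ccccc2)c1` gives 30%. Among these three numbers compound 3 stands second highest. Its nearest neighbour is compound 1, whose number lies a little higher but within the usual scatter, so no order between those two can be claimed. The furthest is compound 2, whose number lies lower by an amount beyond the scatter.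

Compound 4 `COc1ccc(OC)c(N2C(=O)CSC2c2cccc(C(=O)NCCCCc3ccccc3)c2)c1` has not yet been measured. It differs from compound 3 in a single place: methoxy in place of methyl on an aromatic carbon. Among the compounds with values here, no measured pair in this set shows this same change, so its size cannot be read from the data; what remains is that both the leaving group and the entering group are small and sit on the same aromatic carbon. In this assay the expectation is therefore a step of no size beyond the scatter, in either direction, from compound 3 to compound 4. For compound 4 the estimated value is 28%, with a range from 12% to 45%. The expected step of a number 2 percentage points lower from compound 3 to compound 4 (within the scatter) is accordingly small.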

Compound 4, a percentage reported as inhibition, at one concentration (the size of the read-out at that concentration, not a potency): 1%
The estimate for compound 4 lay 27 percentage points above the measured number; measured number outside the range, below it.
By their numbers in this assay, from the lowest: compound 4; then compound 2; then compounds 3 and 1 (each within the scatter of the next).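

In this assay, within the data shown here, going from 2-methoxy-5-methylphenyl to 2,5-dimethoxyphenyl brings a number 29 percentage points lower from compound 3 to compound 4 (beyond the scatter), which is the first direct reading of any change at this place on the shared core. It shows that this aromatic carbon, para to a methoxy group and meta to a large group, is sensitive: replacing a methyl with a methoxy, one heavy atom with two, one of them an oxygen, is enough to move the number well beyond the scatter. At the one concentration tested, compound 4 gives 1% and so keeps almost none of the inhibition seen with compound 3, which means that this small exchange is not a neutral one in this series.

Nothing available here accounts for the size of this drop. On these data alone, it remains open whether the loss follows the oxygen itself or holds more widely at this carbon, and a hydroxyl, an ethyl, a chlorine or an amine in the same place would each give a further reading on how much change this position accepts.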